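The source may hold more compounds than are shown below. What is called first, only, known or untested is meant among the compounds shown, and "the series" means these compounds.

Compound 1 `Cc1cccc(COc2ccc(/C=C/C(/C=C/c3ccccn3)=N/Oc3ncnc4cccc(C)c34)cc2)c1` gives 97% in a functional assay on SMMC-7721 cells (Homo sapiens) for inhibition, read by MTT assay, with a stated time of 72 h, tested at 10 uM; a lower number here means a weaker effect, a higher number a stronger effect of the compound at the concentration tested.
Compound 2 `Clc1ccc(COc2ccc(/C=C/C(/C=C/c3cccs3)=N/Oc3ncnc4ccccc34)cc2)cc1` gives 97.5% in this assay.
Compound 3 `Cc1cccc2ncnc(O/N=C(/C=C/c3ccc(OCc4ccccc4Cl)cc3)\C=C\c3ccccn3)c12` gives 84.7% in this assay.

Among these three numbers compound 1 stands second highest. Its nearest neighbour is compound 2, whose value lies within the scatter of that of compound 1, so the two cannot be told apart. The furthest is compound 3, reached by the step of a number 12.3 percentage points lower from compound 1 to compound 3 (beyond the scatter), a modest loss that lies beyond the scatter.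

Compound 4 `Cc1cccc(COc2ccc(/C=C/C(/C=C/c3ccccn3)=N/Oc3ncnc4cc(Cl)ccc34)cc2)c1` is the unmeasured compound. It differs from compound 1 in one place: 7-chloroquinazolin-4-yl in place of 5-methylquinazolin-4-yl on an oxygen. For the measured compounds named here, this change sits on the shared core, at the oxygen joined to the double-bonded nitrogen, and not at the saturated chain carbon where the only measured step, a number 12.3 percentage points lower from compound 1 to compound 3 (beyond the scatter), was taken. Going by the values given here, no measured pair therefore speaks to a change at this oxygen, and the one measured step is of limited bearing. With compound 1 already close to complete inhibition, the room for a rise is small, and I expect no step beyond the scatter, perhaps a slight fall, a number 5 percentage points lower from compound 1 to compound 4 (within the scatter). For compound 4 the estimated value is 92%, with a range from 78% to 99%.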

Compound 4, a percentage reported as inhibition, at one concentration (the size of the read-out at that concentration, not a potency): 95.6%
Compound 4: middle estimate off by 3.6 percentage points, on the low side; the measured number falls inside the stated range.
By their numbers in this assay, from the lowest: compound 3; then compounds 4, 1 and 2 (each within the scatter of the next).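

In this assay, for the compounds shown here, 7-chloroquinazolin-4-yl in place of 5-methylquinazolin-4-yl on the oxygen gives a number 1.4 percentage points lower from compound 1 to compound 4 (within the scatter), the first measured evidence that the shared core can take a change at this place without a loss that can be resolved from the scatter. The swap keeps the heavy-atom count, the ring types and the hydrogen-bond donor and acceptor counts, but it changes both the substituent and where it sits on the quinazoline, and the single tested concentration shows only that the read-out stays high at that concentration, not that the two compounds would have an equally strong effect at other concentrations. No measurement at hand explains why this step stays so small.

The compounds shown leave open whether the methyl-to-chlorine exchange or the shift in substituent position matters more, a question that 5-chloroquinazolin-4-yl and 7-methylquinazolin-4-yl would help separate. They also leave open whether this position would hold up with a very different substituent, such as an amine or a carboxylic acid, and whether lower concentrations would separate compound 1 from compound 4.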